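Swapping a propyl chain for a thiophene carbonyl group

A few compounds are considered here, and "the series" means these few. Any claim that something is new, unique, unknown or untested is made for them only; others in the source may bear on it.

Of the compounds shown here, three sharing one core have been tested in a functional assay (trachea) with Cavia porcellus as the target; on this read-out higher numbers stand for weaker inhibition and lower numbers for stronger inhibition. Compound 1 `CCCn1nc(-c2cccnc2)c2ccccc2c1=O` carries a propyl chain on a ring nitrogen and gives 3160 nM in this assay, the lowest number of the three and therefore the strongest inhibition seen so far. Compound 2 `CCCCCCCCn1nc(-c2cccnc2)c2ccccc2c1=O` gives 21900 nM, and compound 3 `CC(=O)OCCn1nc(-c2cccnc2)c2ccccc2c1=O` gives 9770 nM.

The new compound 4 `O=C(c1cccs1)n1nc(-c2cccnc2)c2ccccc2c1=O` keeps the core but replaces the propyl chain at the ring nitrogen: (thiophen-2-yl)carbonyl in place of propyl on an aromatic nitrogen.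

Two earlier steps that start from the same propyl chain are relevant. Lengthening it gave a 6.9-fold higher number from compound 1 to compound 2 (0.84 log units; beyond the scatter), and exchanging its end for an acetoxy group gave a 3.1-fold higher number from compound 1 to compound 3 (0.49 log units; beyond the scatter). Every change tried at this chain has therefore raised the number in this assay by a modest amount. The thiophene carbonyl group is a larger and different kind of replacement, so the size of the step is uncertain, but the direction suggested by compound 2 and compound 3 is toward weaker inhibition. Compound 4 is therefore expected to show a 2.5-fold higher number from compound 1 to compound 4 (0.40 log units; beyond the scatter), with an estimated value of 8000 nM and a likely range from 2500 nM to 25000 nM.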

Compound 4, half-maximal inhibitory concentration: 12300 nM
The estimate for compound 4 lay 1.5-fold (0.19 log units) below the measured number; low and high end bracket the measured number.
By their numbers in this assay, from the lowest: compound 1; then compounds 3, 4 and 2 (each within the scatter of the next, the first and the last beyond it).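

The (thiophen-2-yl)carbonyl group is the only one of the four at this position that carries a ring and joins through a carbonyl straight onto the aromatic nitrogen, yet in this assay the change from propyl gives a 3.9-fold higher number from compound 1 to compound 4 (0.59 log units; beyond the scatter) and leaves propyl with the strongest inhibition of the set. This very different group does not stand apart from the two longer chains, with a 1.3-fold higher number from compound 3 to compound 4 (0.10 log units; within the scatter) and a 1.8-fold lower number from compound 2 to compound 4 (0.25 log units; within the scatter), even though compound 2 and compound 3 differ from each other beyond the scatter. No measurement here explains why any of these replacements gives a higher number than propyl.

The compounds shown cannot separate the part played by the thiophene ring from that of the carbonyl, which a simple acetyl or a thiophen-2-ylmethyl group on the same nitrogen could do. As far as these compounds go, it also remains open whether any group at this position can give a lower number than propyl, for example a shorter ethyl chain or a chain ending in an amine.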